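A few compounds are considered here, and "the series" means these few. Any claim that something is new, unique, unknown or untested is made for them only; others in the source may bear on it.

Compound 1 `COC(=O)c1ccc(NC(=O)Nc2cc(C)nc3ccccc23)cc1`: 20000 nM
Compound 2 `Cc1cc(NC(=O)Nc2cc(Cl)cc(Cl)c2)c2ccccc2n1`: > 25000 nM, a limit of the assay

Both compounds were tested in an ADME assay on HepG2 cells (Homo sapiens) for cytotoxicity, with a stated time of 72 h; on this read-out lower numbers stand for an effect already at smaller amounts and higher numbers for an effect only at larger amounts of compound. Among the measured compounds shown here, compound 1 gives the only actual number in this small set, 20000 nM. Compound 2 is reported only as a limit, > 25000 nM.

Compound 3 `Cc1cc(NC(=O)Nc2ccc(C(=O)O)cc2)c2ccccc2n1` has yet to be measured. It departs from compound 1 by hydrogen in place of methyl on an oxygen next to a carbonyl group, with hydrogen in place of methyl on an oxygen next to a carbonyl group, so that methoxycarbonyl becomes carboxy. For the measured compounds named here, no measured pair of compounds shows what a change of this kind does in this assay, so the expectation remains loose. The estimated step of a 1.5-fold higher number from compound 1 to compound 3 (0.18 log units; within the scatter) is expected to be small, pointing toward higher numbers, and it may not exceed the usual scatter. Compound 3 is expected at 30000 nM, with an estimated range of 12000 nM to 75000 nM.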

Compound 3, half-maximal effective concentration: > 25000 nM
Compound 3 was reported as a limit (the forecaster's own chance of this, stated with the estimate: 60%); the middle value does not contradict the limit.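

Setting hydrogen in place of methyl on an oxygen next to a carbonyl group, so that methoxycarbonyl becomes carboxy, gives the first reading of this change in this assay, with an at least 1.2-fold higher number from compound 1 to compound 3 (0.09 log units; that floor lies within the scatter) as its step. That step is only a floor, and since the floor lies within the scatter, it cannot be called a real shift. The result shows that this change at this place did not bring the effect to smaller amounts of compound, but its true size remains unread, and the assay's limit is the reason: the limit of > 25000 nM in this assay, at which 2 of the 3 values shown sit.

As far as these compounds go, how far past the limit compound 3 truly lies stays open. So does what a primary amide or a longer ester such as ethoxycarbonyl would do in place of the carboxy group.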